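A trimethoxyphenyl variant of compound 3: an expectation

The compounds below may be only part of what the source reports. "The series", "measured", "known", "first", "only" and "open" are said of these compounds alone.

Compound 1 `COc1cc(-n2nnnc2-c2ccc(OCC3CC(c4cccc(Cl)c4)=NO3)c(N)c2)cc(OC)c1OC` gives 1340 nM in a functional assay on A549 cells (Homo sapiens) for cytotoxicity, read by MTT assay, with a stated time of 48 h; on this read-out higher numbers stand for weaker inhibition and lower numbers for stronger inhibition.
Compound 2 `COc1ccc(OC)c(C2=NOC(COc3ccc(-c4nnnn4-c4cc(OC)c(OC)c(OC)c4)cc3N)C2)c1` gives 1930 nM in this assay.
Compound 3 `COc1ccc(F)c(C2=NOC(COc3ccc(-c4nnnn4-c4cc(OC)c(OC)c(OC)c4)cc3N)C2)c1` gives 1510 nM in this assay.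

Compound 3 stands second highest of these three numbers. Its nearest neighbour is compound 1 and its furthest is compound 2, and both gaps lie within the scatter, so the three compounds cannot be placed in any order of strength.

Compound 4 `COc1cc(-n2nnnc2-c2ccc(OCC3CC(c4ccc(OC)c(OC)c4OC)=NO3)c(N)c2)cc(OC)c1OC` differs from compound 3 in one place: 2,3,4-trimethoxyphenyl in place of 2-fluoro-5-methoxyphenyl on a carbon with a double bond to nitrogen.

Within the data shown here, every measured step so far alters this same aryl group, and none moved the number beyond the scatter: a 1.4-fold higher number from compound 1 to compound 2 (0.16 log units; within the scatter); a 1.1-fold higher number from compound 1 to compound 3 (0.05 log units; within the scatter); a 1.3-fold lower number from compound 2 to compound 3 (0.11 log units; within the scatter). Three different aryl groups on this carbon all gave numbers close together. A fourth aryl group is therefore expected to behave alike, with no step beyond the scatter in this assay, in either direction.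

Compound 4 is thus estimated at about 1600 nM, with a range from 700 nM to 3600 nM. This estimate means an expected step of a 1.1-fold higher number from compound 3 to compound 4 (0.03 log units; within the scatter).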

Compound 4, half-maximal inhibitory concentration: 2030 nM
Estimate against measurement, compound 4: 1.3-fold (0.10 log units) below, and the stated range covers the measured number.
By their numbers in this assay, from the lowest: compounds 1, 3, 2 and 4 (each within the scatter of the next).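

In this assay, the 2,3,4-trimethoxyphenyl group joins the other aryl groups on this carbon, with a 1.3-fold higher number from compound 3 to compound 4 (0.13 log units; within the scatter) and a 1.1-fold higher number from compound 2 to compound 4 (0.02 log units; within the scatter) and also a 1.5-fold higher number from compound 1 to compound 4 (0.18 log units; within the scatter) as its steps. Among these compounds, the position therefore accepts a group of 12 heavy atoms and 3 hydrogen-bond acceptors, in place of 9 heavy atoms and 1 acceptor, with no step beyond the scatter, which the smaller aryl groups of the earlier compounds could not show. No measurement at hand explains this flat result.

Every group shown here on this carbon is a substituted phenyl ring, so it remains open whether a cyclohexyl group, a longer alkyl chain or a phenyl ring bearing a carboxylic acid would stay within the scatter too. Every step also falls at this one place, so the compounds say nothing about changes elsewhere on the shared core.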